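This account rests on a few compounds, and the source may have more. Where it says the series, first, only, none or still open, it means among the compounds named here.

Measured compounds:
compound 1 `Cc1cc(N2CC[C@@H](C)[C@@H](N(C)c3ncnc4[nH]ccc34)C2)n2nc(SCc3ccccc3Br)nc2n1`: 27000 nM
compound 2 `COc1ccc(CSc2nc3nc(C)cc(N4CC[C@@H](C)[C@@H](N(C)c5ncnc6[nH]ccc56)C4)n3n2)cc1`: 15200 nM
compound 3 `CCCSc1nc2nc(C)cc(N3CC[C@@H](C)[C@@H](N(C)c4ncnc5[nH]ccc45)C3)n2n1`: 15500 nM

All three were tested in a functional assay on MGC-803 cells (Homo sapiens) for inhibition, read by MTT assay, with a stated time of 72 h; on this read-out higher numbers stand for weaker inhibition and lower numbers for stronger inhibition. Compound 1 stands highest of the three numbers, yet its steps to the others are small: a 1.8-fold lower number from compound 1 to compound 2 (0.25 log units; within the scatter) and a 1.7-fold lower number from compound 1 to compound 3 (0.24 log units; within the scatter), while between the other two there is a 1.0-fold higher number from compound 2 to compound 3 (0.01 log units; within the scatter). Among the measured compounds shown here, in each case the only change is the group on a saturated chain carbon bound to a sulfur, and none of these changes moves the number beyond the scatter.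

Compound 4 `C#CSc1nc2nc(C)cc(N3CC[C@@H](C)[C@@H](N(C)c4ncnc5[nH]ccc45)C3)n2n1` differs from compound 1 at that same sulfur: ethynyl in place of 2-bromobenzyl on a sulfur. All three measured steps bear on this change, since each of them also swaps the group carried by the sulfur, and each stayed within the scatter. An ethynyl group has not been measured here, so the expectation rests on that pattern alone. For compound 4 in this assay no step beyond the scatter is expected, a 1.4-fold lower number from compound 1 to compound 4 (0.13 log units; within the scatter). Compound 4 is therefore estimated at 20000 nM, within a range of 8000 nM to 50000 nM.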

Compound 4, half-maximal inhibitory concentration: 18100 nM
Compound 4: the middle estimate sits 1.1-fold (0.04 log units) above what was measured; measured number inside the range.
By their numbers in this assay, from the lowest: compounds 2, 3, 4 and 1 (each within the scatter of the next).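

In this assay, trimming the group on the sulfur from 2-bromobenzyl, with its aromatic ring, to ethynyl, with no ring and a triple bond, gives a 1.5-fold lower number from compound 1 to compound 4 (0.17 log units; within the scatter) and so leaves the number essentially unchanged. Ethynyl also matches the propyl and 4-methoxybenzyl groups, with a 1.2-fold higher number from compound 3 to compound 4 (0.07 log units; within the scatter) and a 1.2-fold higher number from compound 2 to compound 4 (0.08 log units; within the scatter), so this position has now tolerated a much smaller group, and a triple bond, without any step beyond the scatter in these four compounds. No supporting evidence is available to explain this flat result.

On these data alone, whether an amine or a carboxylic acid carried on the sulfur, or a chain longer than propyl, would shift the number beyond the scatter remains open. So does whether replacing the sulfur itself with an oxygen would do so.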